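Hydroxymethyl analogue of a benzoxaborole series in cytotoxicity

A few compounds are considered here, and "the series" means these few. Any claim that something is new, unique, unknown or untested is made for them only; others in the source may bear on it.

Compound 1 `OB1OCc2ccc(-n3cccc3Sc3ccc(Cl)cc3)cc21`, compound 2 `O=C(c1ccc(F)cc1)c1ccn(-c2ccc3c(c2)B(O)OC3)c1` and compound 3 `Cc1ccc(C(=O)c2ccn(-c3ccc4c(c3)B(O)OC4)c2)cc1` share one core and were tested in an ADME assay on L929 cells (Mus musculus) for cytotoxicity, read by resazurin assay, with a stated time of 72 h; a higher number here means a weaker inhibitor, a lower number a stronger inhibitor. Compound 1 gives > 10 ug/mL, a limit of the assay and not a number. Compound 2 gives > 10 ug/mL, again a limit of the assay. Compound 3 gives > 10 ug/mL, also a limit of the assay. Compound 3 therefore stands at the limit of > 10 ug/mL in this assay, at which 3 of the 3 values shown sit, with no number that would place it apart from the other two. The step that the two limits leave unreadable from compound 2 to compound 3 cannot be read because both ends are limits. Compound 4 `O=C(c1ccc(CO)cc1)c1ccn(-c2ccc3c(c2)B(O)OC3)c1` differs from compound 3 by hydroxy in place of hydrogen on a saturated chain carbon bound to an aromatic carbon. Going by the values given here, no measured step bears on this change, and the single measured step in this assay has no readable size, so nothing points to a step beyond the scatter in either direction. Compound 4 is accordingly expected to show a step that the limit leaves unreadable from compound 3 to compound 4 that stays within the scatter. The estimate for compound 4 is 25 ug/mL, with a range from 10 ug/mL to 100 ug/mL, most likely reported again only as a limit.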

Compound 4, half-maximal inhibitory concentration: 9.31 ug/mL
Compound 4: middle estimate off by 2.7-fold (0.43 log units), on the high side; measured number outside the range, below it.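

In this assay, going by these compounds alone, the change from 4-methylphenyl to 4-(hydroxymethyl)phenyl yields the first number in this set, with compound 4 at 9.31 ug/mL. Hydroxy in place of hydrogen on a saturated chain carbon bound to an aromatic carbon gives an at least 1.0-fold lower number from compound 3 to compound 4 (0.03 log units; that floor lies within the scatter), and hydroxymethyl in place of fluoro on an aromatic carbon gives an at least 1.0-fold lower number from compound 2 to compound 4 (0.03 log units; that floor lies within the scatter). Each step has a limit of the assay at one end, so only its floor can be read, and the other three compounds still give no number: the limit of > 10 ug/mL in this assay, at which 3 of the 4 values shown sit.

Going by these compounds, whether either change truly moves the number beyond the scatter therefore remains open. On these data alone, how an amine, a carboxylic acid or a longer chain would read at this place also remains open.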